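Dithiocarbamate-triazole series: swapping the benzyl on the triazole

A few compounds are considered here, and "the series" means these few. Any claim that something is new, unique, unknown or untested is made for them only; others in the source may bear on it.

Measured so far in a functional assay on ECa-109 cells (Homo sapiens) for inhibition, read by MTT assay, with a stated time of 72 h; a lower number here means a stronger inhibitor, a higher number a weaker inhibitor:
- compound 1 `COc1ccc(Cn2cc(CSC(=S)N3CCN(C(=O)OCc4ccccc4)CC3)nn2)cc1` — 58300 nM
- compound 3 `COc1ccc(Cn2cc(CSC(=S)N3CCN(C(=O)OC(C)(C)C)CC3)nn2)cc1` — 36800 nM
- compound 2 `S=C(SCc1cn(Cc2ccc(Cl)c(Cl)c2)nn1)N1CCNCC1` — > 128000 nM (a limit of the assay, not a number)

Among the two numbers, compound 1 stands highest; compound 3 lies nearest, and the step of a 1.6-fold lower number from compound 1 to compound 3 (0.20 log units; within the scatter) stays within the scatter. Within the data shown here, compound 2, with its free piperazine and 3,4-dichlorobenzyl, reaches only the limit described in the limit of > 128000 nM in this assay, at which 1 of the 3 values shown sits; it differs from compound 1 in two places at once, so no single step to it is available.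

Compound 4 `O=C(OCc1ccccc1)N1CCN(C(=S)SCc2cn(Cc3ccccc3Cl)nn2)CC1` is to be measured in this assay. It differs from compound 1 by 2-chlorophenyl in place of 4-methoxyphenyl on a saturated chain carbon bound to an aromatic nitrogen. Among the measured compounds shown here, none of the measured steps touches the benzyl on the triazole; the one measured step, from the benzyl carbamate to the tert-butyl carbamate, concerns the other end of the shared core and was within the scatter. No direction is therefore supported, and the step of a 1.0-fold higher number from compound 1 to compound 4 (0.01 log units; within the scatter) is expected to stay within the scatter. Compound 4 is estimated at 60000 nM, with a range of 25000 nM to 150000 nM, and a real chance that only a limit is returned.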

Compound 4, half-maximal inhibitory concentration: 56800 nM
Estimate against measurement, compound 4: 1.1-fold (0.02 log units) above; the range from low to high includes it.
By their numbers in this assay, from the lowest: compounds 3, 4 and 1 (each within the scatter of the next). At a limit, above all of these: compound 2.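

At the benzyl on the triazole, this assay now gives a first step, a 1.0-fold lower number from compound 1 to compound 4 (0.01 log units; within the scatter). Among these compounds, the earlier step touched only the carbamate end of the shared core, so this pair is the first reading at this position: 2-chlorobenzyl and 4-methoxybenzyl cannot be told apart here, even though the methoxy oxygen leaves and a chlorine enters. Nothing at hand bears on why these two groups read alike.

On these data alone, whether an amine or a carboxylic acid on the phenyl ring, or a longer chain in place of the benzyl, would move the number beyond the scatter remains open. Also open, as far as these compounds go, is whether 2-chlorobenzyl reads the same alongside the tert-butyl carbamate of compound 3.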